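Acetylation and silyl protection in a cytotoxic lactone series

The source may report more compounds than this note shows. Statements on the series, on what has been measured and on what is new or still open speak of the compounds shown alone.

The study compares four compounds built on one shared core. Compound 1 `C=C1CC[C@@H]2[C@](C)(CO[Si](c3ccccc3)(c3ccccc3)C(C)(C)C)[C@H](OC(C)=O)CC[C@@]2(C)[C@@H]1C/C=C1/C(=O)OC[C@H]1O` carries a silyl ether, while compound 2 `C=C1CC[C@@H]2[C@](C)(CO)[C@H](OC(C)=O)CC[C@@]2(C)[C@@H]1C/C=C1/C(=O)OC[C@H]1O` carries a free alcohol in its place; the difference between these two cores is not broken down here. Compound 3 `C=C1CC[C@@H]2[C@](C)(CO)[C@H](OC(C)=O)CC[C@@]2(C)[C@@H]1C/C=C1/C(=O)OC[C@H]1OC(C)=O` differs from compound 2 by acetyl in place of hydrogen on an oxygen on a saturated carbon. In a functional assay on Lu1 cells (Homo sapiens) for cytotoxicity, read by sulforhodamine B assay (on this read-out higher numbers stand for an effect only at larger amounts of compound and lower numbers for an effect already at smaller amounts), compound 2 gives 30.6 uM, compound 3 gives 8.75 uM, and compound 1 gives 10.9 uM, so compound 1 and compound 3 lie within the usual scatter of each other. Among the measured compounds shown here, the one measured instance of the acetylation reads a 3.5-fold lower number from compound 2 to compound 3 (0.54 log units; beyond the scatter).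

Compound 4 `C=C1CC[C@@H]2[C@](C)(CO[Si](c3ccccc3)(c3ccccc3)C(C)(C)C)[C@H](OC(C)=O)CC[C@@]2(C)[C@@H]1C/C=C1/C(=O)OC[C@H]1OC(C)=O` has not yet been measured. It differs from compound 1 by acetyl in place of hydrogen on an oxygen on a saturated carbon, the same change as that from compound 2 to compound 3. For the measured compounds named here, because the measured instance gave a 3.5-fold lower number from compound 2 to compound 3 (0.54 log units; beyond the scatter), compound 4 is expected to show a 2.7-fold lower number from compound 1 to compound 4 (0.44 log units; beyond the scatter) in this assay, with a somewhat wider range since only one example supports the step. Compound 4 is thus estimated at 4 uM in this assay, expected to fall between 1.5 uM and 11 uM.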

Compound 4, concentration for half-maximal effect: 52.9 uM
Compound 4: the middle estimate sits 13-fold (1.12 log units) below what was measured, outside the stated range (above it).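

Acetyl in place of hydrogen on an oxygen on a saturated carbon did not behave on the core of compound 1 as it had on the core of compound 2: in this assay it gave a 4.9-fold higher number from compound 1 to compound 4 (0.69 log units; beyond the scatter). Set beside the earlier step, the same change moved the number in opposite directions on the two cores: the same change on two cores in this assay, a 3.5-fold lower number (0.54 log units; beyond the scatter) from compound 2 to compound 3 and a 4.9-fold higher number (0.69 log units; beyond the scatter) from compound 1 to compound 4, 17-fold (1.23 log units) apart, beyond the scatter of two such steps. Among the compounds shown here, this shows that the effect of the acetylation measured on one core cannot be carried over to the other, but with only two pairs, which differ in a silyl ether against a free alcohol, it does not show that this difference is the reason, nor what the change would do on any further core.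

The compounds shown leave open how a longer acyl chain such as butanoyl, or a benzoyl group, would behave on the same oxygen on either core. They also leave open whether a smaller silyl ether, such as trimethylsilyl, or a methyl ether in place of the large silyl ether would follow compound 1 or compound 2.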